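The source may hold more compounds than are shown below. What is called first, only, known or untested is meant among the compounds shown, and "the series" means these compounds.

Of the compounds shown here, two built on the same core have so far been tested in a functional assay on CHO cells for antagonist activity at Orexin/Hypocretin receptor type 1 (Homo sapiens), read by FLIPR and calcium flux; on this read-out lower numbers stand for stronger inhibition and higher numbers for weaker inhibition. Compound 1 `Cc1occc1-c1nnc(SCC(=O)Nc2cccc(F)c2)n1Cc1ccco1` is reported only as a limit in this assay, > 15800 nM. Compound 2 `Cc1occc1-c1nnc(SCC(=O)Nc2cccc(Cl)c2)n1Cc1ccco1` gives 2000 nM in this assay, the only true number among the two results shown. The other result belongs to compound 1, which is reported at the limit of > 15800 nM in this assay, at which 1 of the 2 values shown sits. Among the measured compounds shown here, the single measured step, an at least 7.9-fold lower number from compound 1 to compound 2 (0.89 log units; beyond the scatter), is a swap of one halogen for another on the ring attached to the amide nitrogen.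

Compound 3 `COc1ccc(NC(=O)CSc2nnc(-c3ccoc3C)n2Cc2ccco2)cc1` has not yet been measured. It differs from compound 2 by 4-methoxyphenyl in place of 3-chlorophenyl on an amide-type nitrogen. For the measured compounds named here, no measured step covers this change: the one step on record, an at least 7.9-fold lower number from compound 1 to compound 2 (0.89 log units; beyond the scatter), exchanges halogens and says nothing about a methoxy group. What it does show is that a small change on this phenyl ring shifted the number beyond the scatter, so a change beyond the scatter is also expected here, with a weakening judged the more likely direction. The expected step is a 4.0-fold higher number from compound 2 to compound 3 (0.60 log units; beyond the scatter). Compound 3 is estimated to give about 8000 nM in this assay, within a range from 2500 nM to 25000 nM.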

Compound 3, inhibition constant: > 15800 nM
Compound 3 ended at the assay's limit; the forecaster's own chance of this, stated with the estimate: 40%; at least 1.9-fold (0.29 log units) between middle value and limit.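

Replacing 3-chlorophenyl with 4-methoxyphenyl on the amide-type nitrogen gives an at least 7.9-fold higher number from compound 2 to compound 3 (0.89 log units; beyond the scatter) in this assay, so a change at this nitrogen other than a swap of halogens also moves the number beyond the scatter. Among the compounds shown here, compound 2 is now the only one of the three compounds with a true number, while compound 1 and compound 3 are both reported as limits: the limit of > 15800 nM in this assay, at which 2 of the 3 values shown sit. Since both of those results are limits, the step from compound 1 to compound 3 cannot be read, and the 3-fluorophenyl and 4-methoxyphenyl groups cannot be ranked against each other.

The change from compound 2 to compound 3 alters both the substituent and the place it occupies on the phenyl ring, so the compounds shown do not separate these two changes; a 4-chlorophenyl or a 3-methoxyphenyl group on the same nitrogen would do so. Also open, as far as these compounds go, is how a 3-bromophenyl or a 3-(trifluoromethyl)phenyl group would read out here, and whether any group at this position can bring the number lower than the value of compound 2, 2000 nM.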